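This account rests on a few compounds, and the source may have more. Where it says the series, first, only, none or still open, it means among the compounds named here.

In a physicochemical assay for metabolic stability, read by HPLC (on this read-out lower numbers stand for a shorter-lived compound and higher numbers for a longer-lived compound), compound 1 `Cc1cn([C@H]2C[C@H](N=[N+]=[N-])[C@@H](COP(=O)(O)Oc3ccncc3)O2)c(=O)[nH]c1=O` gives 8.07 h, compound 3 `Cc1cn([C@H]2C[C@H](N=[N+]=[N-])[C@@H](COP(=O)(O)Oc3ccccc3)O2)c(=O)[nH]c1=O` gives 9.47 h and compound 2 `Cc1cn([C@H]2C[C@H](N=[N+]=[N-])[C@@H](COP(=O)(O)Oc3cccnc3)O2)c(=O)[nH]c1=O` gives 3.88 h. Compound 1 thus sits in the upper pair of these three numbers: within the scatter lies a 1.2-fold higher number from compound 1 to compound 3 (0.07 log units; within the scatter), while beyond it lie a 2.1-fold lower number from compound 1 to compound 2 (0.32 log units; beyond the scatter) and a 2.4-fold higher number from compound 2 to compound 3 (0.39 log units; beyond the scatter). Compound 4 `Cc1ncccc1OP(=O)(O)OC[C@H]1O[C@@H](n2cc(C)c(=O)[nH]c2=O)C[C@@H]1N=[N+]=[N-]` differs from compound 1 as follows: 2-methylpyridin-3-yl in place of pyridin-4-yl on an oxygen, with 2-methylpyridin-3-yl in place of pyridin-4-yl on an oxygen. For the measured compounds named here, the closest guide is a 2.1-fold lower number from compound 1 to compound 2 (0.32 log units; beyond the scatter), which also brings in a pyridin-3-yl ring, though no measured compound carries the 2-methylpyridin-3-yl group. A modest drop in this assay is therefore expected, namely a 1.8-fold lower number from compound 1 to compound 4 (0.25 log units; within the scatter). For compound 4 the estimated half-life is 4.5 h, with an expected range from 2.3 h to 9 h.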

Compound 4, half-life: 15.8 h
Compound 4: the middle estimate sits 3.5-fold (0.55 log units) below what was measured; the measured number lies above the stated range.
By their numbers in this assay, from the lowest: compound 2; then compounds 1, 3 and 4 (each within the scatter of the next).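

In this assay, for the compounds shown here, methyl in place of hydrogen on an aromatic carbon of the pyridin-3-yl group is the one new step beyond the scatter (a 4.1-fold higher number from compound 2 to compound 4 (0.61 log units; beyond the scatter)), so the low number of compound 2 does not extend to the 2-methylpyridin-3-yl group on this oxygen. Against the other two groups on this oxygen, the new group stays within the scatter (a 2.0-fold higher number from compound 1 to compound 4 (0.29 log units; within the scatter) and a 1.7-fold higher number from compound 3 to compound 4 (0.22 log units; within the scatter)). Nothing at hand bears on why the methyl step occurs.

Open, going by these compounds, is whether an ethyl, a methoxy or a chlorine in place of this methyl would give a similar step. Also open, on these data alone, is what methyl would do on the pyridin-4-yl group of compound 1.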